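The source may report more compounds than this note shows. Statements on the series, on what has been measured and on what is new or still open speak of the compounds shown alone.

In an ADME assay on MDBK cells (Bos taurus) for cytotoxicity (a lower number here means that less compound is tolerated, a higher number that more compound is tolerated), compound 1 `COc1ccc(Cn2ccc3nc(-c4ccccc4)nc-3c2)cc1` gives > 100000 nM, which is a limit and not a number. Compound 2 `Clc1ccc(Cn2ccc3nc(-c4ccccc4)nc-3c2)cc1` gives > 100000 nM, again a limit. For the measured compounds named here, compound 3 `Brc1ccc(Cn2ccc3nc(-c4ccccc4)nc-3c2)cc1` gives 83000 nM, the only actual number so far. The remaining values offer little resolution: the limit of > 100000 nM in this assay, at which 2 of the 3 values shown sit.

Compound 4 `CC(C)(C)c1ccc(Cn2ccc3nc(-c4ccccc4)nc-3c2)cc1` is not yet measured. The change is tert-butyl in place of bromo on an aromatic carbon, para to a large group.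

The measured steps that bear on this position are an at least 1.2-fold lower number from compound 2 to compound 3 (0.08 log units; that floor lies within the scatter) and an at least 1.2-fold lower number from compound 1 to compound 3 (0.08 log units; that floor lies within the scatter). The third is a step that the two limits leave unreadable from compound 1 to compound 2. None of them shows a change beyond the scatter, and none involves tert-butyl. A step within the scatter is therefore expected in this assay, with no direction favoured, and the result may again be reported only as a limit. The expected step is a 1.0-fold lower number from compound 3 to compound 4 (0.02 log units; within the scatter). Compound 4 is estimated at 80000 nM, with an expected range of 35000 nM to 150000 nM.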

Compound 4, half-maximal cytotoxic concentration: 22000 nM
Compound 4: the middle estimate sits 3.6-fold (0.56 log units) above what was measured; the measured number lies below the stated range.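

In this assay, for the compounds shown here, the aromatic carbon para to a large group now shows a change beyond the scatter, which no earlier step did: a 3.8-fold lower number from compound 3 to compound 4 (0.58 log units; beyond the scatter). Tert-butyl also stands beyond the scatter against the other two groups, with an at least 4.5-fold lower number from compound 2 to compound 4 (0.65 log units; beyond the scatter) and an at least 4.5-fold lower number from compound 1 to compound 4 (0.65 log units; beyond the scatter). These last two steps give only floors, not full sizes: the limit of > 100000 nM in this assay, at which 2 of the 4 values shown sit.

With tert-butyl as the only group of its kind here, the compounds shown do not tell whether the lower number is particular to tert-butyl or also comes with other carbon groups at this position, such as methyl or isopropyl. On these data alone, how an amine or a carboxylic acid on the same carbon would read in this assay also stays open.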